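Methoxy Added to an Aryl Amide: Cytotoxicity Expectation

A few compounds are considered here, and "the series" means these few. Any claim that something is new, unique, unknown or untested is made for them only; others in the source may bear on it.

Compound 1, `CCCCNc1nc(N)nc2cccc(OCc3ccccc3)c12`, gives 10000 nM in an ADME assay on HEK293 cells (Homo sapiens) for cytotoxicity, with a stated time of 6 h; on this read-out lower numbers stand for higher toxicity in this test and higher numbers for lower toxicity in this test.
Compound 2, `CCCCNc1nc(N)nc2cccc(OCc3ccccc3OC)c12`, reaches only the limit of > 25000 nM in this assay.
Compound 3, `CCCCNc1nc(N)nc2cccc(C(=O)N[C@@H](C)c3ccccc3)c12`, reaches only the limit of > 25000 nM in this assay.

The first two compounds share a core and differ by methoxy in place of hydrogen on an aromatic carbon. That change gives an at least 2.5-fold higher number from compound 1 to compound 2 (0.39 log units; beyond the scatter), which rests on (the limit of > 25000 nM in this assay, at which 2 of the 3 values shown sit). Compound 3 carries a different side piece; the difference between the two cores is not broken down here. Compound 4, `CCCCNc1nc(N)nc2cccc(C(=O)N[C@@H](C)c3cccc(OC)c3)c12`, has not yet been measured in this assay. It differs from compound 3 by methoxy in place of hydrogen on an aromatic carbon. Among the compounds with values here, this is the same kind of change as the one from compound 1 to compound 2, though not the same: in compound 2 the methoxy sits ortho to a large group, whereas in compound 4 it sits meta to a large group.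

Compound 3 already sits at the limit, so the expected step that the limit leaves unreadable from compound 3 to compound 4 cannot be fixed in size, and compound 4 is expected to remain at or beyond that limit. On that basis compound 4 is estimated at 30000 nM in this assay, with a range from 15000 nM to 80000 nM, because the earlier methoxy step an at least 2.5-fold higher number from compound 1 to compound 2 (0.39 log units; beyond the scatter) pointed toward lower toxicity.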

Compound 4, half-maximal cytotoxic concentration: > 25000 nM
Compound 4: a limit, no number; the forecaster's own chance of this, stated with the estimate: 75%; the middle value is on the limit's open side.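

No step from compound 3 to compound 4 can be read in this assay, because both compounds stop at a limit of the assay rather than giving a number: the limit of > 25000 nM in this assay, at which 3 of the 4 values shown sit.

The compounds shown leave open how far compound 3 and compound 4 lie past that limit, and so whether the change from phenyl to 3-methoxyphenyl moves the read-out at all.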